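The source may report more compounds than this note shows. Statements on the series, on what has been measured and on what is new or still open speak of the compounds shown alone.

Compound 2 `O=C(CC1CCOCC1)N1CCc2nc(C#Cc3ccccc3)sc2C1` gives 470 nM in an assay on HEK293 cells for positive allosteric modulation of metabotropic glutamate receptor 5 (Homo sapiens), read by FLIPR, with a stated time of 1 h; a lower number here means that less compound is needed, a higher number that more compound is needed for the effect. Its nearest neighbour, compound 1 `O=C(C1CCCCO1)N1CCc2nc(C#Cc3ccccc3)sc2C1`, gives 320 nM in this assay, so compound 2 holds the higher of the two numbers, though the step of a 1.5-fold higher number from compound 1 to compound 2 (0.17 log units; within the scatter) is within the scatter. Compound 3 `Cc1cccc(C(=O)N2CCc3nc(C#Cc4ccccc4)sc3C2)n1` differs from compound 2 in one place: 6-methylpyridin-2-yl in place of (oxan-4-yl)methyl on a carbonyl carbon. Going by the values given here, only one measured step exists, and it exchanges one six-membered non-aromatic ring with an oxygen for another of the same kind; it tells little about a move to a six-membered aromatic ring with a nitrogen, and it was itself within the scatter. Among the compounds with values here, with no step reaching beyond the scatter, a change for compound 3 of no more than the scatter is expected, with the direction open, which is written as a 1.2-fold lower number from compound 2 to compound 3 (0.07 log units; within the scatter). Compound 3 is therefore estimated at 400 nM in this assay, within a range from 100 nM to 1600 nM.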

Compound 3, half-maximal effective concentration: 160 nM
Compound 3: middle estimate off by 2.5-fold (0.40 log units), on the high side; low and high end bracket the measured number.
By their numbers in this assay, from the lowest: compounds 3, 1 and 2 (each within the scatter of the next, the first and the last beyond it).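

Going by these compounds alone, at this position, on a carbonyl carbon whose other neighbour is the amide-type nitrogen in a ring, the group does matter in this assay: 6-methylpyridin-2-yl in place of (oxan-4-yl)methyl gives a 2.9-fold lower number from compound 2 to compound 3 (0.47 log units; beyond the scatter), the first step here to pass the scatter, though only a modest one. The same group in place of oxan-2-yl gives a 2.0-fold lower number from compound 1 to compound 3 (0.30 log units; within the scatter), so the aromatic ring separates compound 3 from compound 2 only, and the data do not set it apart from compound 1. Nothing available accounts for this step.

From the compounds shown here alone, what a phenyl or an unsubstituted pyridin-2-yl group would give on this carbonyl carbon remains open, and with it whether the methyl or the ring nitrogen of compound 3 carries the step. Also open, going by these compounds, is how a saturated amine such as a piperidine ring would compare here.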